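The source may report more compounds than this note shows. Statements on the series, on what has been measured and on what is new or still open speak of the compounds shown alone.

Working notes on the series.

Compound 1 `Cc1ccc(C(=O)NC(=N)NCCCCc2ccccc2)cc1` is the reference point. For the measured compounds named here, in a functional assay on the whole organism for inhibition, with Mus musculus as the target, at a dose of 20 mg/kg by the intraperitoneal route (a higher number here means more inhibition at the dose given (going by the name of the read-out), a lower number less inhibition), compound 1 gives 75%, which stands highest of the two numbers so far. The nearest is compound 2 `CCOc1ccc(C(=O)NC(=N)NCCCCc2ccccc2)cc1`, which in this assay gives 60%. Going by the values given here, the only step between measured compounds is a number 15 percentage points lower from compound 1 to compound 2 (beyond the scatter), and it concerns a substituent on the aromatic ring, not the ring itself.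

Compound 3 `N=C(NCCCCc1ccccc1)NC(=O)c1ccco1` is the next compound to be measured. It differs from compound 1 in one place: furan-2-yl in place of 4-methylphenyl on a carbonyl carbon. Among the compounds with values here, no measured step bears directly on exchanging the ring on the carbonyl carbon; the one step available, a number 15 percentage points lower from compound 1 to compound 2 (beyond the scatter), only shows that a change at this end of the molecule moved the inhibition by a modest amount beyond the scatter and downward.

On that basis a modest downward step is expected, a number 15 percentage points lower from compound 1 to compound 3 (beyond the scatter), though the direction rests on a single step and is uncertain. Compound 3 is therefore estimated to give 60% in this assay, with a range from 35% to 85%.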

Compound 3, a percentage reported as inhibition, in the whole organism at one dose (the size of the read-out at that dose, not a potency): 5%
The estimate for compound 3 lay 55 percentage points above the measured number; the measured number lies below the stated range.
By their numbers in this assay, from the lowest: compound 3; then compound 2; then compound 1.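

In this assay, for the compounds shown here, the ring on the carbonyl carbon proves far more sensitive than the earlier compounds showed: the exchange of 4-methylphenyl for furan-2-yl gives a number 70 percentage points lower from compound 1 to compound 3 (beyond the scatter), a large step, against the modest a number 15 percentage points lower from compound 1 to compound 2 (beyond the scatter) for a substituent change on the ring. Among the compounds shown, replacing the ring itself therefore costs much more than changing its substituent, and compound 3 keeps little inhibition at this dose, with 5%. This single exchange alters ring size, brings in a ring oxygen and removes the methyl group all at once, so it cannot separate these changes, and no measurement at hand explains the step.

The compounds shown leave open whether an unsubstituted phenyl or a thiophen-2-yl on the carbonyl carbon would keep the inhibition of compound 1, which would help separate the loss of the methyl group and the six-membered ring from the entry of the oxygen. Also open, going by these compounds, is whether a furan-3-yl would behave like furan-2-yl.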